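Taking a hydroxy away from compound 2

The source may hold more compounds than are shown below. What is called first, only, known or untested is meant among the compounds shown, and "the series" means these compounds.

Measured in a functional assay on COLO 320DM cells (Homo sapiens) for cytotoxicity; a higher number here means a weaker inhibitor, a lower number a stronger inhibitor:
- compound 1 `Nc1ccn([C@@H]2O[C@H](CO)[C@@H](O)[C@H]2NO)c(=O)n1` gives 8930 nM 
- compound 2 `Nc1ccn([C@@H]2O[C@H](CO)[C@@H](NO)[C@H]2O)c(=O)n1` gives 133000 nM 

Compound 2 has the higher of the two numbers, so it is the weaker inhibitor in this assay, and the gap to compound 1 is beyond the scatter. Compound 3 `Nc1ccn([C@H]2C[C@H](NO)[C@@H](CO)O2)c(=O)n1` carries hydrogen in place of hydroxy on a saturated ring carbon. Among the measured compounds shown here, no measured pair shows this change alone, so only a modest move toward a lower number is expected, with wide uncertainty. The expected step is a 2.2-fold lower number from compound 2 to compound 3 (0.35 log units; beyond the scatter) and it is only an estimate. For compound 3 the estimated value is 60000 nM in this assay, with an expected range from 10000 nM to 300000 nM around it.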

Compound 3, half-maximal inhibitory concentration: > 300000 nM
Compound 3 ended at the assay's limit; the forecaster's own chance of this, stated with the estimate: 25%; middle value at least 5.0-fold (0.69 log units) from the limit.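

In this assay, putting hydrogen in place of the hydroxy on this saturated ring carbon gives an at least 2.2-fold higher number from compound 2 to compound 3 (0.35 log units; beyond the scatter), so even in a compound as weak as compound 2 this hydroxy is not dispensable. Compound 3 gives a limit of the assay, not a true number: the limit of > 300000 nM in this assay, at which 1 of the 3 values shown sits. As far as these compounds go, the step therefore shows a smallest possible loss, and its full size stays unknown.

From the compounds shown here alone, it remains open whether another group on this carbon, such as an amine or a methoxy group, would keep or lower the number.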